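A few compounds are considered here, and "the series" means these few. Any claim that something is new, unique, unknown or untested is made for them only; others in the source may bear on it.

Measured compounds and their values:
Compound 1 `COc1cc(C(=O)/C=C/c2ccc(N(C)C)cc2)cc(OC)c1OC` – 75000 nM
Compound 2 `COc1cccc(/C=C/C(=O)c2cc(OC)c(OC)c(OC)c2)c1O` – 13000 nM

In a functional assay on COLO 205 cells (Homo sapiens) for inhibition, read by MTT assay, with a stated time of 48 h (a lower number here means a stronger inhibitor, a higher number a weaker inhibitor), compound 1 gives 75000 nM as the higher of the two numbers, which makes it the weaker inhibitor of the pair. Compound 2 at 13000 nM lies lower, with a gap beyond the scatter.

Compound 3 `COc1cc(C(=O)/C=C/c2ccc(F)cc2)cc(OC)c1OC` has not yet been measured. It keeps the core of compound 1 and carries fluoro in place of dimethylamino on an aromatic carbon, para to a large group (fluoro in place of dimethylamino on an aromatic carbon). Going by the values given here, no measured pair differing in one place shows what such a change does, so the size of the step remains uncertain. With compound 1 at 75000 nM at the upper end of the two numbers and compound 2 at 13000 nM well lower, a move toward a lower number looks more likely than a move higher. An estimated step of a 3.0-fold lower number from compound 1 to compound 3 (0.48 log units; beyond the scatter) in this assay is expected, toward a stronger inhibitor and modestly beyond the scatter. The estimate for compound 3 is 25000 nM (expected range 7000 nM to 80000 nM).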

Compound 3, half-maximal inhibitory concentration: 25700 nM
Compound 3: middle estimate off by 1.0-fold (0.01 log units), on the low side, within the range that was stated.
By their numbers in this assay, from the lowest: compounds 2 and 3 (each within the scatter of the next); then compound 1.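

In this assay, fluoro in place of dimethylamino on an aromatic carbon, para to a large group, gives a 2.9-fold lower number from compound 1 to compound 3 (0.47 log units; beyond the scatter), a modest step toward a stronger inhibitor that lies beyond the scatter. Going by these compounds alone, this is the first comparison in the set that differs in one place only, and it shows that activity on the shared core responds to the group at this position, with the smaller fluoro giving the lower number of the pair. No measurement here bears on why the exchange has this effect, so the step stands as an observation without an explanation.

On these data alone, this single step cannot separate the contributions of the departing dimethylamino and the incoming fluoro, so it remains open whether removing the former or adding the latter accounts for the change. It also leaves open how a methoxy group, a chlorine atom, a primary amine or a plain hydrogen at this position would compare, and whether the same exchange would produce a similar step on the core of compound 2.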